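This account rests on a few compounds, and the source may have more. Where it says the series, first, only, none or still open, it means among the compounds named here.

Three compounds carry the shared core of compound 1 `O=C1/C(=C/c2ccccc2F)CN(S(=O)(=O)c2ccccc2)C/C1=C\c1ccccc1F`, which in a functional assay on SMMC-7721 cells (Homo sapiens) for cytotoxicity, read by MTT assay, with a stated time of 24 h (a higher number here means a weaker inhibitor, a lower number a stronger inhibitor), gives 5700 nM. Compound 2 `O=C1/C(=C/c2ccccc2F)CN(S(=O)(=O)c2ccc(C(F)(F)F)cc2)C/C1=C\c1ccccc1F` adds a trifluoromethyl group to the phenylsulfonyl ring and in this assay gives 5200 nM. Compound 3 `O=C1/C(=C/c2cccc(F)c2)CN(S(=O)(=O)c2ccccc2)C/C1=C\c1cccc(F)c1`, in which both fluorine atoms sit in the other position of their rings, gives 12900 nM in this assay. Compound 3 thus stands at the highest of the three numbers, beyond the scatter from both compound 1 and compound 2.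

Compound 4 `N#Cc1ccc(S(=O)(=O)N2C/C(=C\c3cccc(F)c3)C(=O)/C(=C/c3cccc(F)c3)C2)cc1` has not yet been measured. It differs from compound 3 in one place: cyano in place of hydrogen on an aromatic carbon. Going by the values given here, the only measured step that bears on this is the one from compound 1 to compound 2, where a trifluoromethyl group entered at the same kind of position on the same ring; that step was a 1.1-fold lower number from compound 1 to compound 2 (0.04 log units; within the scatter). Among the compounds with values here, a substituent on this ring therefore did not move the number beyond the scatter in the one case where it was tried, and no measured step shows what a cyano group in particular does.

On this basis, compound 4 is expected to give about 12000 nM in this assay, within a range of 5000 nM to 28000 nM, meaning an expected step of a 1.1-fold lower number from compound 3 to compound 4 (0.03 log units; within the scatter) that stays within the scatter.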

Compound 4, half-maximal inhibitory concentration: 4500 nM
For compound 4 the middle estimate is 2.7-fold (0.43 log units) above the measured one, outside the stated range (below it).
By their numbers in this assay, from the lowest: compounds 4, 2 and 1 (each within the scatter of the next); then compound 3.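

In this assay, cyano in place of hydrogen on this aromatic carbon, para to a large group, gives a 2.9-fold lower number from compound 3 to compound 4 (0.46 log units; beyond the scatter), a modest step but the first at this place to pass beyond the scatter. The earlier step on the same ring, a 1.1-fold lower number from compound 1 to compound 2 (0.04 log units; within the scatter), had stayed within the scatter, so the phenylsulfonyl ring can no longer be read as a part of the molecule where substitution leaves the number unchanged, although this holds for only one of the two substituents shown. Nothing available explains why the cyano step passes beyond the scatter while the trifluoromethyl step does not.

The two steps differ both in the entering group and in where the fluorine atoms sit on their rings, so the compounds shown cannot tell whether the larger step belongs to cyano itself or depends on the fluorine arrangement of compound 3. They also leave open what other groups at this place, such as an amine, a carboxylic acid or a longer chain, would do to the number.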